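Methyl added to the chlorophenyl urea of compound 1

This account rests on a few compounds, and the source may have more. Where it says the series, first, only, none or still open, it means among the compounds named here.

Measured so far:
compound 1 `O=C(Nc1cccc(Cl)c1)Nc1nnc(Sc2ncnc3scc(-c4ccncc4)c23)s1`: 22900 nM
compound 2 `O=C(Nc1cccc(C(F)(F)F)c1)Nc1nnc(Sc2ncnc3scc(-c4ccncc4)c23)s1`: 15300 nM

In a functional assay on HepG2 cells (Homo sapiens) for antiproliferative activity, read by MTT assay, with a stated time of 48 h (a higher number here means a weaker inhibitor, a lower number a stronger inhibitor), compound 1 gives 22900 nM and compound 2 gives 15300 nM. Among the measured compounds shown here, the only step known, a 1.5-fold lower number from compound 1 to compound 2 (0.18 log units; within the scatter), is within the scatter, so the two values sit together. Compound 3 `Cc1ccc(NC(=O)Nc2nnc(Sc3ncnc4scc(-c5ccncc5)c34)s2)cc1Cl` differs from compound 1 by methyl in place of hydrogen on an aromatic carbon, taking 3-chlorophenyl to 3-chloro-4-methylphenyl. For the measured compounds named here, no measured step touches this change; the one step known is flat. A step of a 1.1-fold lower number from compound 1 to compound 3 (0.06 log units; within the scatter) is therefore expected, none beyond the scatter. Compound 3 is estimated at 20000 nM, in the range 8000 nM to 50000 nM.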

Compound 3, half-maximal inhibitory concentration: 16000 nM
For compound 3 the middle estimate is 1.3-fold (0.10 log units) above the measured one, within the range that was stated.
By their numbers in this assay, from the lowest: compounds 2, 3 and 1 (each within the scatter of the next).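

In this assay, methyl on the aromatic carbon ortho to a chloro group and para to a large group gives a 1.4-fold lower number from compound 1 to compound 3 (0.16 log units; within the scatter), so this position tolerates the added methyl with no step beyond the scatter. 3-Chloro-4-methylphenyl in place of 3-(trifluoromethyl)phenyl gives a 1.0-fold higher number from compound 2 to compound 3 (0.02 log units; within the scatter), and all three compounds sit together. No evidence bears on why these values stay together. Still open, from the compounds shown here alone, is whether an amine or a carboxylic acid at this position would give a step beyond the scatter. Equally open, going by these compounds, is whether any change away from this phenyl ring would do so.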